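Cytotoxicity of a pyrazolopyridine amide series: toward a fluoropyridyl analogue

A few compounds are considered here, and "the series" means these few. Any claim that something is new, unique, unknown or untested is made for them only; others in the source may bear on it.

Compound 1 `CC(C)n1ncc2c(C(=O)Nc3ccc(F)c(S(N)(=O)=O)c3)cc(-c3cccs3)nc21` — 50000 nM in an ADME assay on LLC-MK2 cells (Macaca mulatta) for cytotoxicity, read by spectrophotometry and crystal violet staining, with a stated time of 4 days; on this read-out lower numbers stand for higher toxicity in this test and higher numbers for lower toxicity in this test
Compound 2 `CC(C)n1ncc2c(C(=O)Nc3cccc(S(N)(=O)=O)c3)cc(-c3cccs3)nc21` — 25000 nM
Compound 3 `CC(C)n1ncc2c(C(=O)Nc3ccc(F)c(F)c3)cc(-c3cccs3)nc21` — > 200000 nM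

In this assay compound 3 gives only a limit, > 200000 nM, and no number. The two steps that reach compound 3 both raise the number: an at least 4.0-fold higher number from compound 1 to compound 3 (0.60 log units; beyond the scatter) and an at least 8.0-fold higher number from compound 2 to compound 3 (0.90 log units; beyond the scatter). Compound 3 therefore stands at the limit of > 200000 nM in this assay, at which 1 of the 3 values shown sits, with no finite value shown.

Compound 4 `CC(C)n1ncc2c(C(=O)Nc3ccc(F)cn3)cc(-c3cccs3)nc21` has not yet been measured. It differs from compound 3 by 5-fluoropyridin-2-yl in place of 3,4-difluorophenyl on an amide-type nitrogen. Among the compounds with values here, no measured step involves a pyridin-2-yl group, so the effect of the ring nitrogen cannot be read from the data. The measured steps show that removing the sulfamoyl group and keeping fluorine leaves the compound at the limit, and compound 4 keeps a fluorinated ring without sulfamoyl. Compound 4 is expected to give 150000 nM (between 50000 nM and 400000 nM), which would be a step of an at least 1.3-fold lower number from compound 3 to compound 4 (0.12 log units; that floor lies within the scatter) if the estimate holds.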

Compound 4, half-maximal cytotoxic concentration: > 200000 nM
Compound 4: a limit, no number (the forecaster's own chance of this, stated with the estimate: 60%); at least 1.3-fold (0.12 log units) between middle value and limit.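

On the amide-type nitrogen, a ring with a hetero atom and no sulfamoyl group also reaches the limit in this assay: the limit of > 200000 nM in this assay, at which 2 of the 4 values shown sit. Putting 5-fluoropyridin-2-yl in place of 3-sulfamoylphenyl gives an at least 8.0-fold higher number from compound 2 to compound 4 (0.90 log units; beyond the scatter), so the rise seen with 3,4-difluorophenyl in compound 3 is not confined to a ring of carbon only. The step between compound 3 and compound 4 cannot be read, as both are limits.

The compounds shown leave open whether the ring nitrogen changes the read-out at all, and how an amine or a carboxylic acid on this ring would behave in this assay.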